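A few compounds are considered here, and "the series" means these few. Any claim that something is new, unique, unknown or untested is made for them only; others in the source may bear on it.

Of the compounds shown here, three of one shared core have been measured in a functional assay on PANC-1 cells (Homo sapiens) for inhibition, read by MTT assay, with a stated time of 24 h, tested at 10 uM; a higher number here means more inhibition at the concentration tested (going by the name of the read-out), a lower number less inhibition. Compound 1 `CCOc1cc(=O)n(CCCO)c2c1CC(CC=C(C)C)C(C)(C)C2` gives 66.5%. Compound 2 `CC(C)=CCC1Cc2c(OCCCNC(=O)c3ccc([N+](=O)[O-])cc3)cc(=O)n(CCCO)c2CC1(C)C` gives 49.9%. Compound 3 `CCOc1cc(=O)n(CCCO)c2c1CC(C/C=C(\C)CCC=C(C)C)C(C)(C)C2` gives 67.8%; among the three numbers it is the highest, yet compound 1 lies within the scatter of it, and only compound 2 lies beyond the scatter below it. Among the compounds with values here, the one step that is fully described, a number 1.3 percentage points higher from compound 1 to compound 3 (within the scatter), concerns the chain and not the oxygen on the aromatic ring.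

The next compound, compound 4 `CC(C)=CCC/C(C)=C/CC1Cc2c(OC(=O)Nc3ccc(F)c(Cl)c3)cc(=O)n(CCCO)c2CC1(C)C`, differs from compound 3 at that oxygen: (3-chloro-4-fluorophenyl)carbamoyl in place of ethyl on an oxygen on an aromatic ring. Within the data shown here, no measured step follows a change at this oxygen. Compound 1 and compound 2 differ there too, and compound 2 sits well below compound 1; this is the only hint. A downward step of modest size is therefore expected, a number 10.8 percentage points lower from compound 3 to compound 4 (beyond the scatter), with wide uncertainty. Compound 4 is expected to give 57%, estimated between 40% and 72% in this assay.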

Compound 4, a percentage reported as inhibition, at one concentration (the size of the read-out at that concentration, not a potency): 25%
Compound 4: middle estimate off by 32 percentage points, on the high side; the measured number lies below the stated range.
By their numbers in this assay, from the lowest: compound 4; then compound 2; then compounds 1 and 3 (each within the scatter of the next).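

Within the data shown here, at the oxygen on an aromatic ring, (3-chloro-4-fluorophenyl)carbamoyl in place of ethyl gives a number 42.8 percentage points lower from compound 3 to compound 4 (beyond the scatter) in this assay, the first step at this oxygen that can be read directly. Among these compounds, the inhibition at the concentration tested therefore depends strongly on what this oxygen carries, whereas the one earlier step, on the chain, stayed within the scatter. No measurement shown here accounts for the size of this fall.

The compounds shown leave open whether the fall belongs to the carbamoyl link or to the 3-chloro-4-fluorophenyl ring it carries. Going by these compounds, what an acetyl group or an unsubstituted phenylcarbamoyl on this oxygen would give remains open, as does the effect of a free hydroxyl there.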